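Swapping one aromatic group on a shared core

The compounds below may be only part of what the source reports. "The series", "measured", "known", "first", "only" and "open" are said of these compounds alone.

Compound 1 `Cc1oc(-c2ccc(Cl)cc2)nc1C(=O)N[C@H]1CN(S(=O)(=O)c2ccccc2)C[C@@H]1C(=O)N[C@H]1CCCNC1` and compound 2 `Cc1oc(-c2ccc(C(F)(F)F)cc2)nc1C(=O)N[C@H]1CN(S(=O)(=O)c2ccccc2)C[C@@H]1C(=O)N[C@H]1CCCNC1` share a core and differ only in the group carried on one aromatic ring. In a physicochemical assay for solubility, at pH 7.4 (a higher number here means a more soluble compound, a lower number a less soluble compound), compound 1 gives 15000 nM and compound 2 gives 13000 nM as its reading. Trifluoromethyl in place of chloro makes a 1.2-fold lower number from compound 1 to compound 2 (0.06 log units; within the scatter) and so compound 2 cannot be separated from compound 1 on these two numbers.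

Compound 3 `Cc1oc(-c2ccccc2Cl)nc1C(=O)N[C@H]1CN(S(=O)(=O)c2ccccc2)C[C@@H]1C(=O)N[C@H]1CCCNC1` keeps the shared core but has 2-chlorophenyl in place of 4-(trifluoromethyl)phenyl on an aromatic carbon of the five-membered aromatic ring with 1 nitrogen and 1 oxygen. Among the compounds with values here, the change is counted as 2-chlorophenyl in place of 4-(trifluoromethyl)phenyl on an aromatic carbon and no measured compound yet carries this new group. Within the data shown here, the only guide is therefore the one measured step, a 1.2-fold lower number from compound 1 to compound 2 (0.06 log units; within the scatter) and it is a swap of a different kind, so it offers only weak support. Nothing in it points to a large move in either direction. The expected change is a 1.2-fold higher number from compound 2 to compound 3 (0.06 log units; within the scatter) and this estimate stays within the scatter. In this assay compound 3 is estimated at 15000 nM with an expected range of 7000 nM to 32000 nM around that figure.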

Compound 3, solubility: 10000 nM
Beside the measured number, compound 3's estimate is 1.5-fold (0.18 log units) above it, and the stated range covers the measured number.
By their numbers in this assay, from the lowest: compounds 3, 2 and 1 (each within the scatter of the next).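

Compound 1 and compound 2 differ only in which group the phenyl ring carries, whereas compound 3 brings a new kind of swap: 2-chlorophenyl in place of 4-chlorophenyl keeps the same chloro group on the phenyl ring but alters where it sits, and this gives a 1.5-fold lower number from compound 1 to compound 3 (0.18 log units; within the scatter) in this assay. The swap of 2-chlorophenyl for 4-(trifluoromethyl)phenyl alters both the group and where it sits, and it gives a 1.3-fold lower number from compound 2 to compound 3 (0.11 log units; within the scatter), so all three compounds remain inseparable in this read-out, and neither kind of swap on this aromatic carbon has yet produced a step beyond the scatter. No independent measurement bears on this result, and the readings alone offer no explanation for it.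

All three groups at this place are phenyl rings carrying a chloro or trifluoromethyl group, or a single ring of carbon with no hydrogen-bond donors or acceptors. As far as these compounds go, it remains open whether a phenyl ring bearing an amine or a carboxylic acid, or a group with no phenyl ring at all, such as a longer chain, would read differently here.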